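Fluoro to ethyl on the aryl ring of compound 2

This account rests on a few compounds, and the source may have more. Where it says the series, first, only, none or still open, it means among the compounds named here.

Measured so far:
compound 1 `CNC(=O)c1cc(Oc2ccc(NC(=O)c3nccc(-c4ccc(OC)cc4)n3)cc2)ccn1` — 11100 nM
compound 2 `CNC(=O)c1cc(Oc2ccc(NC(=O)c3cc(-c4ccc(F)cc4)ncn3)cc2F)ccn1` — > 100000 nM
compound 3 `CNC(=O)c1cc(Oc2ccc(NC(=O)c3nccc(-c4ccccc4)n3)cc2)ccn1` — 26200 nM

Among the measured compounds shown here, in a functional assay on A549 cells (Homo sapiens) for cytotoxicity, read by MTT assay, with a stated time of 72 h (a higher number here means a weaker inhibitor, a lower number a stronger inhibitor), compound 1 gives 11100 nM and compound 3 gives 26200 nM; the step of a 2.4-fold higher number from compound 1 to compound 3 (0.37 log units; beyond the scatter) is the only fully measured comparison in the set. For compound 2 this assay reports only a limit, > 100000 nM, so compound 2 stands at the weak end of what has been seen, as the limit of > 100000 nM in this assay, at which 1 of the 3 values shown sits, records.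

The next compound, compound 4 `CCc1ccc(-c2cc(C(=O)Nc3ccc(Oc4ccnc(C(=O)NC)c4)c(F)c3)ncn2)cc1`, differs from compound 2 by ethyl in place of fluoro on an aromatic carbon. For the measured compounds named here, no measured step changes this position, and the step from compound 1 to compound 3 concerns a different group on a different core, so it bears on the change only as a rough indication that a small substituent change at the outer aryl ring moves the number modestly. With compound 2 itself known only as a limit, no step size can be carried over.

It is therefore expected that compound 4 remains a weak inhibitor, near where compound 2 sits, with the step of an at least 1.1-fold lower number from compound 2 to compound 4 (0.04 log units; that floor lies within the scatter) being the estimate rather than anything measured. Compound 4 is estimated at 90000 nM, within 25000 nM to 300000 nM.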

Compound 4, half-maximal inhibitory concentration: 3390 nM
Estimate against measurement, compound 4: 27-fold (1.42 log units) above; measured number below the stated range.
By their numbers in this assay, from the lowest: compound 4; then compound 1; then compound 3. At a limit, above all of these: compound 2.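

In this assay, the change from 4-fluorophenyl to 4-ethylphenyl on the core of compound 2 is far from neutral, giving an at least 29-fold lower number from compound 2 to compound 4 (1.46 log units; beyond the scatter). This step is only a floor, since compound 2 carries a limit and not a number: the limit of > 100000 nM in this assay, at which 1 of the 4 values shown sits. Among the compounds shown here, the only earlier step at a substituent on the outer aryl ring, a 2.4-fold higher number from compound 1 to compound 3 (0.37 log units; beyond the scatter), is modest and belongs to a different core, so the large step here shows that a modest move on that core does not describe this position on the core of compound 2.

The compounds shown carry only fluoro and ethyl at this position on this core, so they leave open whether the drop in the number belongs to ethyl itself or would also come with methyl, a longer chain such as propyl, or an amine. They also leave open the true size of the step and whether ethyl would give a comparable step on the core of compound 1, where the compounds shown carry only methoxy and hydrogen.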